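Cytotoxicity of piperidinylphenyl thiophenes: a bromo analogue forecast

This account rests on a few compounds, and the source may have more. Where it says the series, first, only, none or still open, it means among the compounds named here.

Measured so far:
compound 1 `O=C(/C=C/c1ccc(N2CCCCC2)cc1)c1ccsc1`, in an ADME assay on Vero cells (Chlorocebus sabaeus) for cytotoxicity, with a stated time of 5 days (on this read-out lower numbers stand for stronger inhibition and higher numbers for weaker inhibition), compound 1 gives 34400 nM
compound 2 `Cc1csc(C2=NNC(c3ccc(N4CCCCC4)cc3)C2)c1`, in this assay compound 2 gives 31600 nM

Compound 2 carries the smaller of the two numbers in this assay, but the gap to compound 1 lies within the scatter, so the two cannot be told apart. Compound 3 `Brc1ccsc1C1=NNC(c2ccc(N3CCCCC3)cc2)C1` differs from compound 2 by 3-bromothiophen-2-yl in place of 4-methylthiophen-2-yl on a carbon with a double bond to nitrogen. Within the data shown here, no step between measured compounds sizes such a change. The step from compound 2 to compound 3 is expected to be a 1.1-fold lower number from compound 2 to compound 3 (0.02 log units; within the scatter), not beyond the scatter. Compound 3 is therefore expected to give 30000 nM, estimated between 12000 nM and 75000 nM.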

Compound 3, half-maximal inhibitory concentration: 24800 nM
Estimate against measurement, compound 3: 1.2-fold (0.08 log units) above, and the stated range covers the measured number.
By their numbers in this assay, from the lowest: compounds 3, 2 and 1 (each within the scatter of the next).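

In this assay, among these compounds, putting 3-bromothiophen-2-yl in place of 4-methylthiophen-2-yl on a carbon with a double bond to nitrogen gives a 1.3-fold lower number from compound 2 to compound 3 (0.11 log units; within the scatter) and is the first step sized at this position. This exchange of one substituted thiophene for another thus leaves compound 2 and compound 3 indistinguishable on this read-out. Nothing available explains this result. The compounds shown leave open whether a group other than a thiophene at this position, such as an unsubstituted phenyl ring or an amine, would shift the number beyond the scatter.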